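Swapping bromo for phenoxy in a weak growth inhibitor

The source may hold more compounds than are shown below. What is called first, only, known or untested is meant among the compounds shown, and "the series" means these compounds.

Within the data shown here, in a functional assay on DU-145 cells (Homo sapiens) for inhibition, read by trypan blue exclusion, with a stated time of 96 h (on this read-out lower numbers stand for stronger inhibition of growth and higher numbers for weaker inhibition of growth), compound 1 `Cc1ccc(S/C(=C/c2ccc(Br)cc2)C(=O)c2ccc(Cl)cc2)cc1` gives 25000 nM, the higher of the two numbers measured so far. In this assay, compound 2 `COc1ccc(/C=C(/Sc2ccc(C)cc2)C(=O)c2ccc(Cl)cc2)cc1O` gives 1000 nM. Among the measured compounds shown here, the one measured step is a 25-fold lower number from compound 1 to compound 2 (1.40 log units; beyond the scatter), a large change beyond the scatter, made by putting 3-hydroxy-4-methoxyphenyl in place of 4-bromophenyl.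

Compound 3 `Cc1ccc(S/C(=C/c2ccc(Oc3ccccc3)cc2)C(=O)c2ccc(Cl)cc2)cc1` keeps the rest of compound 1 but carries phenoxy in place of bromo on an aromatic carbon, para to a large group: phenoxy in place of bromo on an aromatic carbon. For the measured compounds named here, the measured step also replaced the bromine-bearing ring substituent, so it is the only guide here. Going by the values given here, it is a loose guide, however, as no measured compound carries phenoxy. Going by a 25-fold lower number from compound 1 to compound 2 (1.40 log units; beyond the scatter), a smaller step toward a lower number is expected, while a result within the scatter of compound 1 remains possible. The expected change is a 2.1-fold lower number from compound 1 to compound 3 (0.32 log units; beyond the scatter). The estimated value for compound 3 is 12000 nM, with an expected range from 3000 nM to 40000 nM.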

Compound 3, concentration for 50% growth inhibition: 10000 nM
Compound 3: middle estimate off by 1.2-fold (0.08 log units), on the high side, and the stated range covers the measured number.
By their numbers in this assay, from the lowest: compound 2; then compound 3; then compound 1.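

In this assay, replacing bromo with phenoxy gives a 2.5-fold lower number from compound 1 to compound 3 (0.40 log units; beyond the scatter), so this aromatic carbon, para to a large group, takes a group of seven heavy atoms with its own six-membered aromatic ring in place of a single bromine, and the number still falls beyond the scatter. This is the first step shown that changes only one group on that ring and leaves the ring itself in place, which makes it a cleaner reading of this position than the earlier replacement of the whole 4-bromophenyl group. Beside a 25-fold lower number from compound 1 to compound 2 (1.40 log units; beyond the scatter), the phenoxy step is the smaller of the two, so phenoxy alone does not bring the large drop seen with 3-hydroxy-4-methoxyphenyl, and no measurement available here explains the change in either step.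

Still open, as far as these compounds go, is whether the oxygen atom or the added aromatic ring accounts for the lower number, a question that a methoxy group or a plain phenyl group at this position could help to separate. From the compounds shown here alone, it is also open how far this position would tolerate other kinds of group, such as an amine or a carboxylic acid, in place of phenoxy.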